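This account rests on a few compounds, and the source may have more. Where it says the series, first, only, none or still open, it means among the compounds named here.

Compound 1 `O=C(/C=C/c1cccc(O)c1)CC(=O)/C=C/c1cccc(O)c1O`: 8200 nM
Compound 2 `O=C(/C=C/c1cc(O)ccc1O)CC(=O)/C=C/c1cccc(O)c1O`: 100000 nM

Among the measured compounds shown here, in a physicochemical assay for solubility, using the shake flask method, with a stated time of 12 h (on this read-out lower numbers stand for lower solubility and higher numbers for higher solubility), compound 2 gives 100000 nM, the higher of the two numbers so far. Compound 3 `O=C(/C=C/c1cc(O)ccc1O)CC(=O)/C=C/c1cc(O)ccc1O` has the same atoms joined differently, with 2,5-dihydroxyphenyl in place of 2,3-dihydroxyphenyl on a double-bonded chain carbon bound to a double-bonded chain carbon. For the measured compounds named here, the one measured step, a 12-fold higher number from compound 1 to compound 2 (1.09 log units; beyond the scatter), was large, but it put hydroxy in place of hydrogen on an aromatic carbon, and no atom is added here. It is therefore a loose guide, and no shift beyond the scatter is expected, with the estimated step being a 1.2-fold higher number from compound 2 to compound 3 (0.08 log units; within the scatter). Compound 3 is estimated at 120000 nM, with an expected range from 35000 nM to 400000 nM.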

Compound 3, solubility: 5000 nM
Compound 3: middle estimate off by 24-fold (1.38 log units), on the high side, and the stated range ends above it.
By their numbers in this assay, from the lowest: compounds 3 and 1 (each within the scatter of the next); then compound 2.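

Putting 2,5-dihydroxyphenyl in place of 2,3-dihydroxyphenyl at this position gives a large change in this assay (a 20-fold lower number from compound 2 to compound 3 (1.30 log units; beyond the scatter)), although no atom is gained or lost. The two groups have the same printed counts of hydrogen-bond donors and acceptors, so these counts alone do not set the number here. No available measurement bears on the reason for this drop. As far as these compounds go, it remains open how an amine or a carboxylic acid at this position would compare with compound 2 and compound 3.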